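Trimming the Alkenyl Chain on the Amide of Compound 3

The compounds below may be only part of what the source reports. "The series", "measured", "known", "first", "only" and "open" are said of these compounds alone.

Measured compounds:
compound 1, `COc1ccc(CN(C(C)=O)c2cc(OC)c(OC)c(OC)c2)cc1O`, 79 nM
compound 2, `COc1ccc(CN(C(=O)C(C)Br)c2cc(OC)c(OC)c(OC)c2)cc1O`, 120 nM
compound 3, `CC/C=C/C(=O)N(Cc1ccc(OC)c(O)c1)c1cc(OC)c(OC)c(OC)c1`, 58 nM

All three share a core and differ only in the group on the carbonyl carbon of the amide. In a functional assay on MGC-803 cells (Homo sapiens) for inhibition, read by MTT assay, with a stated time of 48 h (on this read-out higher numbers stand for weaker inhibition and lower numbers for stronger inhibition), compound 3 gives the lowest number of the three: against compound 1 the gap is a 1.4-fold lower number from compound 1 to compound 3 (0.13 log units; within the scatter), and against compound 2 it is a 2.1-fold lower number from compound 2 to compound 3 (0.32 log units; beyond the scatter), so only compound 2 is set apart from it beyond the scatter.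

Compound 4, `C/C=C/C(=O)N(Cc1ccc(OC)c(O)c1)c1cc(OC)c(OC)c(OC)c1`, is not yet measured. It differs from compound 3 by hydrogen in place of methyl on a saturated chain carbon bound to a double-bonded chain carbon.

Within the data shown here, the steps that bear on this are those that alter the same carbonyl substituent: a 1.5-fold higher number from compound 1 to compound 2 (0.18 log units; within the scatter) and a 1.4-fold lower number from compound 1 to compound 3 (0.13 log units; within the scatter), both within the scatter, and the modest 2.1-fold lower number from compound 2 to compound 3 (0.32 log units; beyond the scatter). Swapping groups at this position has so far moved the number only a little, so the removal of a single methyl from the but-1-en-1-yl chain is expected to give no step beyond the scatter in this assay, perhaps a slightly higher number. The expected step from compound 3 is a 1.2-fold higher number from compound 3 to compound 4 (0.08 log units; within the scatter). Compound 4 is therefore estimated at 70 nM, within a range from 35 nM to 140 nM.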

Compound 4, half-maximal inhibitory concentration: 27 nM
Estimate against measurement, compound 4: 2.6-fold (0.41 log units) above; measured number below the stated range.
By their numbers in this assay, from the lowest: compound 4; then compounds 3, 1 and 2 (each within the scatter of the next, the first and the last beyond it).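

In this assay the prop-1-en-1-yl group of compound 4 is the first at this carbonyl carbon to stand apart from every other group shown, with a gap beyond the scatter in each comparison (a 2.1-fold lower number from compound 3 to compound 4 (0.33 log units; beyond the scatter); a 2.9-fold lower number from compound 1 to compound 4 (0.47 log units; beyond the scatter); a 4.4-fold lower number from compound 2 to compound 4 (0.65 log units; beyond the scatter)). Removing one methyl from the end of the chain therefore moved the number further than the swap from methyl to but-1-en-1-yl, which stays within the scatter, so the number does not simply follow chain length: compound 4 has the lowest number, while compound 1 and compound 3, on either side of it in chain length, lie within the scatter of each other. No measurement given here explains why this small change has an effect of this size.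

Going by these compounds, it remains open whether the double bond is needed, which a saturated propyl chain at the same carbonyl carbon would address. Also open is how far the trimming can go, since the ethenyl group, which is shorter still but keeps the double bond, is not among the compounds shown.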